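This account rests on a few compounds, and the source may have more. Where it says the series, first, only, none or still open, it means among the compounds named here.

Compound 1 `COc1ccc(-c2cc(/C=C/C(=O)c3cc(OC)c(OC)c(OC)c3)nc3cc(-c4ccccc4)nn23)cc1OC`: 4700 nM
Compound 2 `COc1cc(-c2cc(C(=O)/C=C/c3ccccc3)nc3cc(-c4ccccc4)nn23)cc(OC)c1OC`: 19200 nM

In a functional assay on MDA-MB-231 cells (Homo sapiens) for antiproliferative activity, read by MTT assay, with a stated time of 24 h (a lower number here means a stronger inhibitor, a higher number a weaker inhibitor), compound 1 gives 4700 nM, the lowest of the two numbers recorded. Its nearest neighbour is compound 2, which gives 19200 nM in this assay, a gap that lies beyond the usual scatter of this kind of measurement. Among the compounds with values here, no pair of measured compounds differs in only one place, so the step from compound 1 to compound 3 has no direct precedent among the measured compounds. Compound 3 `COc1ccc(-c2cc(/C=C/C(=O)c3ccc(Cl)cc3)nc3cc(-c4ccccc4)nn23)cc1OC` differs from compound 1 in one place: 4-chlorophenyl in place of 3,4,5-trimethoxyphenyl on a carbonyl carbon. The shared core of compound 1 and compound 3 is otherwise kept. Within the data shown here, with no precedent the size of the step is uncertain, and a modest weakening is expected, estimated as a 1.9-fold higher number from compound 1 to compound 3 (0.28 log units; within the scatter). For compound 3 in this assay the expected value is 9000 nM, with a range from 3000 nM to 30000 nM.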

Compound 3, half-maximal inhibitory concentration: 17100 nM
Beside the measured number, compound 3's estimate is 1.9-fold (0.28 log units) below it; the measured number falls inside the stated range.
By their numbers in this assay, from the lowest: compound 1; then compounds 3 and 2 (each within the scatter of the next).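

The step at this position, where 4-chlorophenyl takes the place of 3,4,5-trimethoxyphenyl on a carbonyl carbon, is a 3.6-fold higher number from compound 1 to compound 3 (0.56 log units; beyond the scatter) in this assay, so the group on this carbonyl carbon does matter to the read-out. The change removes three hydrogen-bond acceptors and five heavy atoms and brings in a chlorine, all in one move, and this single step cannot tell these parts apart. Nothing available here accounts for the shift.

The compounds shown leave open whether a single methoxy group, as in 4-methoxyphenyl, would stay closer to compound 1 or to compound 3. They also leave open how an amine or a carboxylic acid on this ring would behave, and whether the same exchange would give a step of similar size on another core.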